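This account rests on a few compounds, and the source may have more. Where it says the series, first, only, none or still open, it means among the compounds named here.

For the measured compounds named here, in an ADME assay on the whole organism (plasma, Rattus norvegicus) for protein binding, using cassette dosing, at a dose of 1 mg/kg (on this read-out higher numbers stand for a larger free fraction and lower numbers for a smaller free fraction), compound 2 `C[C@@H](Cn1c(=O)[nH]/c(=N\c2ccc(Oc3ccccn3)cc2)n(Cc2ccc(Cl)cc2)c1=O)C(=O)O` gives 0.01, the higher of the two numbers measured so far. Compound 1 `CC(C)Oc1ccc(/N=c2\[nH]c(=O)n(C[C@@H](O)CO)c(=O)n2Cc2ccc(Cl)cc2)cc1Cl` gives 0.001 in this assay, a gap that lies beyond the usual scatter. Compound 3 `C[C@@H](Cn1c(=O)[nH]/c(=N\c2ccc(Oc3ccnc(F)c3)cc2)n(Cc2ccc(Cl)cc2)c1=O)C(=O)O` differs from compound 2 in one place only: 2-fluoropyridin-4-yl in place of pyridin-2-yl on an oxygen on an aromatic ring. Going by the values given here, no measured pair shows this change, so the step of a 1.3-fold lower number from compound 2 to compound 3 (0.10 log units; within the scatter) is expected to be a slight shift toward a smaller free fraction, not beyond the scatter. On that basis compound 3 is estimated at 0.008, with a range from 0.004 to 0.016.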

Compound 3, unbound fraction in the Rattus norvegicus assay: 0.013
Estimate against measurement, compound 3: 1.6-fold (0.21 log units) below; the range from low to high includes it.
By their numbers in the Rattus norvegicus assay, from the lowest: compound 1; then compounds 2 and 3 (each within the scatter of the next).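

The swap of pyridin-2-yl for 2-fluoropyridin-4-yl on an oxygen on an aromatic ring leaves the free fraction in the Rattus norvegicus assay unresolved from that of the parent, with a 1.3-fold higher number from compound 2 to compound 3 (0.11 log units; within the scatter). The same swap does separate the two compounds on another read-out, since in a physicochemical assay for solubility, at pH 6.8 (a lower number here means a less soluble compound, a higher number a more soluble compound), compound 2 gives 458 ug/mL and compound 3 gives 212 ug/mL: the measured solubility of compound 2, 458 ug/mL, and of compound 3, 212 ug/mL, a 2.2-fold lower number (0.33 log units; beyond the scatter)

The compounds shown leave open whether an amine in place of the fluorine would move either read-out beyond the scatter. They also leave open whether a pyrimidine ring on that oxygen would separate the two read-outs in the same way.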